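A few compounds are considered here, and "the series" means these few. Any claim that something is new, unique, unknown or untested is made for them only; others in the source may bear on it.

Of the compounds shown here, three built on one shared core have been tested in a functional assay on A549 cells (Homo sapiens) for cytotoxicity, read by MTT assay, with a stated time of 72 h; on this read-out lower numbers stand for stronger inhibition and higher numbers for weaker inhibition. Compound 1 `Cc1cc(=O)n(-c2ccccc2C(F)(F)F)nc1C(=O)Nc1ccc(Oc2ncnc3sccc23)c(F)c1` gives 16300 nM in this assay. For compound 2 `Cc1cc(=O)n(-c2ccccc2OC(F)(F)F)nc1C(=O)Nc1ccc(Oc2ncnc3sccc23)c(F)c1` this assay reports only a limit, > 40000 nM. Compound 3 `Cc1cc(=O)n(-c2cccc(F)c2)nc1C(=O)Nc1ccc(Oc2ncnc3sccc23)c(F)c1` gives 19500 nM, the higher of the two numbers, with compound 1 as its nearest neighbour; the step of a 1.2-fold higher number from compound 1 to compound 3 (0.08 log units; within the scatter) lies within the scatter, so the two cannot be told apart. The step of an at least 2.0-fold lower number from compound 2 to compound 3 (0.31 log units; beyond the scatter) is at least modest.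

Compound 4 `Cc1ccc(-n2nc(C(=O)Nc3ccc(Oc4ncnc5sccc45)c(F)c3)c(C)cc2=O)cc1` differs from compound 3 by one change: 4-methylphenyl in place of 3-fluorophenyl on an aromatic nitrogen. Both measured steps that vary the ring on this aromatic nitrogen bear on it: a 1.2-fold higher number from compound 1 to compound 3 (0.08 log units; within the scatter) stayed within the scatter, while an at least 2.0-fold lower number from compound 2 to compound 3 (0.31 log units; beyond the scatter) was at least modest. With one small and one modest effect from swaps at this position, no step beyond the scatter is expected in this assay for a methyl in place of a fluorine. Compound 4 is therefore expected to give about 20000 nM, within a range from 8000 nM to 50000 nM. The expected step is a 1.0-fold higher number from compound 3 to compound 4 (0.01 log units; within the scatter).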

Compound 4, half-maximal inhibitory concentration: > 40000 nM
Compound 4 ended at the assay's limit; the forecaster's own chance of this, stated with the estimate: 20%; middle value at least 2.0-fold (0.30 log units) away from the limit.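

This result shows that the ring on this aromatic nitrogen is less forgiving in this assay than compound 1 and compound 3 suggested, since a 4-methylphenyl ring gives a clear loss: an at least 2.0-fold higher number from compound 3 to compound 4 (0.31 log units; beyond the scatter). The same holds against the 2-(trifluoromethyl)phenyl ring, with an at least 2.4-fold higher number from compound 1 to compound 4 (0.38 log units; beyond the scatter). Among these four compounds, a ring carrying a single small group can therefore behave very differently from another such ring, so size alone does not set the outcome here, and the step between compound 2 and compound 4 cannot be read because both stand at a limit: the limit of > 40000 nM in this assay, at which 2 of the 4 values shown sit.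

The 3-fluorophenyl and 4-methylphenyl rings differ in both the group and its place on the ring, so the two effects remain tangled. A 4-fluorophenyl or 3-methylphenyl ring would separate them, and a 4-aminophenyl ring remains an open case.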